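A few compounds are considered here, and "the series" means these few. Any claim that something is new, unique, unknown or untested is made for them only; others in the source may bear on it.

Compound 1 `CN1Cc2c(N)cccc2C(c2ccc(Cl)cc2)C1` gives 1.6 mg/kg in a functional assay on the whole organism for inhibition, with Mus musculus as the target; on this read-out higher numbers stand for an effect only at larger amounts of compound and lower numbers for an effect already at smaller amounts. Compound 2 `CCCCNC(=O)Nc1cccc2c1CN(C)CC2c1ccccc1` gives about 40 mg/kg in this assay, the highest of the two plain numbers shown, well above compound 1. Compound 3 `CCNCCC(=O)Nc1cccc2c1CN(C)CC2c1ccccc1` reaches only a limit of this assay, > 200 mg/kg, and not a number. The step of an at least 5.0-fold higher number from compound 2 to compound 3 (0.69 log units; beyond the scatter) therefore has only a lower bound; its true size cannot be fixed because compound 3 sits at the limit of > 200 mg/kg in this assay, at which 1 of the 3 values shown sits.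

Compound 4 `CCCCNCCC(=O)Nc1cccc2c1CN(C)CC2c1ccccc1` is not yet measured. It differs from compound 2 by 2-(butylamino)ethyl in place of butylamino on a carbonyl carbon. Within the data shown here, the one measured step that bears on this change, an at least 5.0-fold higher number from compound 2 to compound 3 (0.69 log units; beyond the scatter), also turned the butylamino group on the carbonyl carbon into an aminoethyl chain, there a 2-(ethylamino)ethyl, and the number rose beyond the scatter. Compound 4 keeps the butyl part of compound 2 but adds the same kind of chain, so a rise of similar character is expected, a 3.8-fold higher number from compound 2 to compound 4 (0.57 log units; beyond the scatter). For compound 4 the expected result in this assay is 150 mg/kg, with a range from 50 mg/kg to 400 mg/kg.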

Compound 4, dose for half-maximal effect: about 46 mg/kg
Beside the measured number, compound 4's estimate is 3.3-fold (0.51 log units) above it, and the stated range ends above it.
By their numbers in this assay, from the lowest: compound 1; then compounds 2 and 4 (each within the scatter of the next). At a limit, above all of these: compound 3.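

In this assay, replacing butylamino on the carbonyl carbon with 2-(butylamino)ethyl gives a 1.2-fold higher number from compound 2 to compound 4 (0.06 log units; within the scatter) and so makes no measurable difference at this position. Adding an aminoethyl chain therefore does not by itself explain the poor result of compound 3; the group on the amine matters, since the change from 2-(ethylamino)ethyl to 2-(butylamino)ethyl gives an at least 4.3-fold lower number from compound 3 to compound 4 (0.63 log units; beyond the scatter) in the same test. For compound 3 the value is a limit, so this step has only a bound: the limit of > 200 mg/kg in this assay, at which 1 of the 4 values shown sits.

Going by these compounds, it remains open whether a propyl or a pentyl group on the amine nitrogen would behave like the butyl of compound 4 or the ethyl of compound 3. Also open, on these data alone, is whether a dimethylamino group or a carboxylic acid at the end of the chain would keep the value of compound 4.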